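The source may hold more compounds than are shown below. What is called first, only, known or untested is meant among the compounds shown, and "the series" means these compounds.

Measured so far:
compound 1 `O=C(Nc1ccc(Nc2ncnc3c2OCCN3)cc1)Nc1ccc(Cl)c(C(F)(F)F)c1` — 285 nM
compound 2 `COc1cccc(NC(=O)Nc2ccc(Nc3ncnc4c3OCCN4)cc2)c1` — > 10000 nM

In an assay on isolated protein for inhibition of proto-oncogene tyrosine-protein kinase receptor Ret variant V804L (Homo sapiens), read by 33P incorporation, with stated times of 15 min and 40 min (on this read-out higher numbers stand for weaker inhibition and lower numbers for stronger inhibition), compound 1 gives 285 nM. For compound 2 the read-out is a limit of the assay rather than a number, > 10000 nM, that is the limit of > 10000 nM in this assay, at which 1 of the 2 values shown sits. Compound 2 therefore stands at the weak end of the two values shown, and only compound 1 yields an actual number.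

Compound 3 `O=C(Nc1ccc(Nc2ncnc3c2OCCN3)cc1)Nc1cccs1` differs from compound 2 by thiophen-2-yl in place of 3-methoxyphenyl on an amide-type nitrogen. Among the measured compounds shown here, no step between two measured compounds covers this change, so nothing measured speaks for or against it. The step implied by the estimate is an at least 1.2-fold lower number from compound 2 to compound 3 (0.09 log units; that floor lies within the scatter), expected to run toward stronger inhibition but to stay small, quite possibly not beyond the usual scatter. Compound 3 is expected to give 8000 nM, with a range from 2000 nM to 30000 nM, and a limit rather than a number remains a real possibility.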

Compound 3, half-maximal inhibitory concentration: > 10000 nM
Compound 3: only a limit was reported; the forecaster's own chance of this, stated with the estimate: 50%; middle value at least 1.2-fold (0.09 log units) from the limit.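

Compound 3, like compound 2, is reported only as a limit of the assay, so no step can be read between compound 2 and compound 3: the limit of > 10000 nM in this assay, at which 2 of the 3 values shown sit. Going by these compounds, whether thiophen-2-yl and 3-methoxyphenyl on an amide-type nitrogen differ at all on this read-out stays open.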